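This account rests on a few compounds, and the source may have more. Where it says the series, first, only, none or still open, it means among the compounds named here.

Compound 2 `O=C1N(Cc2ccccc2Cl)c2cccn2S(=O)(=O)N1Cc1ccccc1` was examined in an ADME assay on MT4 cells (Homo sapiens) for cytotoxicity, read by MTT assay, with a stated time of 5 days; a lower number here means that less compound is tolerated, a higher number that more compound is tolerated. In this assay compound 2 gives > 291000 nM, which is a limit of the assay rather than a measured number. Its nearest measured relative is compound 1 `C=CCN1C(=O)N(Cc2ccccc2)S(=O)(=O)n2cccc21`, which carries vinyl where compound 2 carries 2-chlorophenyl on a saturated chain carbon bound to an amide-type nitrogen in a ring. In this assay compound 1 gives > 802000 nM, likewise a limit. The step that the two limits leave unreadable from compound 1 to compound 2 cannot be sized because the limit of > 291000 nM in this assay, at which 1 of the 2 values shown sits, and the limit of > 802000 nM in this assay, at which 1 of the 2 values shown sits, each hold one of the two values. Compound 3 `N#Cc1ccccc1CN1C(=O)N(Cc2ccccc2)S(=O)(=O)n2cccc21` differs from compound 2 by cyano in place of chloro on an aromatic carbon. Going by the values given here, no measured step bears directly on this exchange, and the single step available is unreadable. Compound 3 is therefore expected to remain at a limit in this assay, the expected step being a step that the limit leaves unreadable from compound 2 to compound 3. The estimate for compound 3 is 300000 nM, within 100000 nM to 1000000 nM.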

Compound 3, half-maximal cytotoxic concentration: > 318000 nM
Compound 3: a limit, no number (the forecaster's own chance of this, stated with the estimate: 85%); at least 1.0-fold (0.02 log units) between middle value and limit.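

In this assay compound 3 gives > 318000 nM, which is a limit and not a number. Going by these compounds alone, compound 1 and compound 2 also stand at limits, and no step to compound 3 can be read. The compounds shown leave open at what concentration any of the three becomes cytotoxic, and whether cyano and chloro differ at all.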